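Pyridin-2-yl for 2-methylphenyl on the alkyne

This account rests on a few compounds, and the source may have more. Where it says the series, first, only, none or still open, it means among the compounds named here.

Compound 3 `Cc1ccccc1C#Cc1ccc2c(n1)CCN(C1CCCCC1)C2=O` carries a cyclohexyl on the amide-type ring nitrogen of the shared core. In an assay on HEK293 cells for displacement of a labelled ligand from metabotropic glutamate receptor 5 (Homo sapiens), with a stated time of 2 h (a higher number here means a weaker inhibitor, a lower number a stronger inhibitor), compound 3 gives only a limit, > 32000 nM. Compound 1 `Cc1ccccc1C#Cc1ccc2c(n1)CCN(C)C2=O` also returns a limit, > 32000 nM. Compound 2 `Cc1ccccc1C#Cc1ccc2c(n1)CCN(C(C)C)C2=O` likewise sits at a limit, > 32000 nM. The steps a step that the two limits leave unreadable from compound 1 to compound 2, a step that the two limits leave unreadable from compound 1 to compound 3 and a step that the two limits leave unreadable from compound 2 to compound 3 are therefore unreadable; all three values rest at the limit of > 32000 nM in this assay, at which 3 of the 3 values shown sit. Compound 4 `O=C1c2ccc(C#Cc3ccccn3)nc2CCN1C1CCCCC1` differs from compound 3 by pyridin-2-yl in place of 2-methylphenyl on a triple-bonded carbon. For the measured compounds named here, no measured step touches this position, so nothing in the numbers speaks for a move away from the limit. Compound 4 is expected to stay near the limit, with an expected step of a number no higher from compound 3 to compound 4 (the limit leaves the size open). The estimate for compound 4 in this assay is 32000 nM, range 6000 nM to 100000 nM.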

Compound 4, inhibition constant: 2240 nM
For compound 4 the middle estimate is 14-fold (1.15 log units) above the measured one; measured number outside the range, below it.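

In this assay, pyridin-2-yl in place of 2-methylphenyl on a triple-bonded carbon gives an at least 14-fold lower number from compound 3 to compound 4 (1.15 log units; beyond the scatter). This position therefore moves the read-out, whereas the steps among the groups on the amide-type ring nitrogen cannot be read. Compound 4 is the only compound shown that stands off the limit: the limit of > 32000 nM in this assay, at which 3 of the 4 values shown sit.

From the compounds shown here alone, whether the step comes from the pyridine nitrogen or from the loss of the methyl stays open; an unsubstituted phenyl on the triple-bonded carbon would separate the two. Also open, going by these compounds, is whether pyridin-2-yl gives a readable value with methyl or isopropyl on the ring nitrogen.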